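A few compounds are considered here, and "the series" means these few. Any claim that something is new, unique, unknown or untested is made for them only; others in the source may bear on it.

Of the compounds shown here, two built on the same core have been measured so far. In a physicochemical assay for solubility, read by HPLC, in phosphate buffer, with a stated time of 24 h, at pH 7.4, tested at 100 uM (on this read-out lower numbers stand for lower solubility and higher numbers for higher solubility), compound 1 (`O=C(CCCCCNc1c(Nc2ccc(C(F)(F)F)cc2)c(=O)c1=O)NO`) gives 4500000 nM, and compound 2 (`CCC(CCCCC(=O)NO)Nc1c(Nc2ccc(C(F)(F)F)cc2)c(=O)c1=O`) gives 6600000 nM. These two values lie within the scatter of each other, so compound 2 stands level with compound 1 on the numbers available.

Compound 3 (`CC(C)C(CCCCC(=O)NO)Nc1c(Nc2ccc(C(F)(F)F)cc2)c(=O)c1=O`) is the next to be measured, and it turns the ethyl of compound 2 into isopropyl: methyl in place of hydrogen on a saturated chain carbon bound to two saturated chain carbons. In words, this is methyl in place of hydrogen on a saturated chain carbon bound to two saturated chain carbons.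

For the measured compounds named here, only one measured step bears on this change, the replacement of hydrogen by ethyl, which gave a 1.5-fold higher number from compound 1 to compound 2 (0.17 log units; within the scatter). That single step stayed within the scatter, and it is too little to set a direction for the further methyl. No shift beyond the scatter is therefore expected in this assay. The expected step is a 1.1-fold lower number from compound 2 to compound 3 (0.03 log units; within the scatter).

For compound 3 the estimated value is 6200000 nM, with an expected range of 2800000 nM to 13000000 nM.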

Compound 3, solubility: 5300000 nM
The estimate for compound 3 lay 1.2-fold (0.07 log units) above the measured number; measured number inside the range.
By their numbers in this assay, from the lowest: compounds 1, 3 and 2 (each within the scatter of the next).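

In this assay, the step from ethyl to isopropyl on a saturated chain carbon bound to two saturated chain carbons gives a 1.2-fold lower number from compound 2 to compound 3 (0.10 log units; within the scatter), and the whole replacement of hydrogen by isopropyl gives a 1.2-fold higher number from compound 1 to compound 3 (0.07 log units; within the scatter). Where the earlier pair offered a single substitution at this position, there are now two groups of different size, ethyl and isopropyl, and neither they nor the added methyl produce a step beyond the scatter, so compound 1, compound 2 and compound 3 stand level on this read-out. No measured evidence is available to explain these small steps.

The compounds shown leave open whether an amine, a carboxylic acid or a longer chain at this position would give a step beyond the scatter, since ethyl and isopropyl are the only groups seen there. They also leave open whether the same level picture would hold for a change made elsewhere on the shared core, as every step here concerns this one carbon.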